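From 3-Chlorophenyl to 3,4-Dichlorophenyl: Compound 3 Awaited

The source may report more compounds than this note shows. Statements on the series, on what has been measured and on what is new or still open speak of the compounds shown alone.

Measured so far:
compound 1 `O=C(NO)c1ccc(NCc2nc(-c3ccco3)nn2-c2ccccc2)cc1` gives 59.9%
compound 2 `O=C(NO)c1ccc(NCc2nc(-c3cccc(Cl)c3)nn2-c2ccccc2)cc1` gives 61.2%

Both numbers come from an assay on Sf9 cells for inhibition of protein deacetylase HDAC6 (Homo sapiens), read by fluorescence, with a stated time of 40 min, tested at 100 nM (a lower number here means less inhibition, a higher number more inhibition at the concentration tested (going by the name of the read-out)), in which compound 1 gives 59.9% and compound 2 gives 61.2%. Compound 2 stands beside compound 1 rather than apart from it: the step of a number 1.3 percentage points higher from compound 1 to compound 2 (within the scatter) lies within the scatter, so these two numbers do not separate the compounds. That step swapped a whole group, furan-2-yl for 3-chlorophenyl, on the shared core.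

Compound 3 `O=C(NO)c1ccc(NCc2nc(-c3ccc(Cl)c(Cl)c3)nn2-c2ccccc2)cc1` differs from compound 2 in one place: chloro in place of hydrogen on an aromatic carbon. Cut one bond further out, the same change reads 3-chlorophenyl to 3,4-dichlorophenyl. Going by the values given here, no measured step adds a second chloro to this group, so the only guide is indirect: exchanging the entire group gave a number 1.3 percentage points higher from compound 1 to compound 2 (within the scatter), a step within the scatter. A single added chloro is a smaller change than that, so the step of a number 0.8 percentage points higher from compound 2 to compound 3 (within the scatter) is expected to stay within the scatter as well. Compound 3 is therefore estimated at 62%, with a range from 48% to 76%.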

Compound 3, a percentage reported as inhibition, at one concentration (the size of the read-out at that concentration, not a potency): 34.5%
For compound 3 the middle estimate is 27.5 percentage points above the measured one; measured number below the stated range.
By their numbers in this assay, from the lowest: compound 3; then compounds 1 and 2 (each within the scatter of the next).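

In this assay one added chloro, placed ortho to a chloro group and para to a large group, gives a number 26.7 percentage points lower from compound 2 to compound 3 (beyond the scatter) and so moves the number beyond the scatter, which the exchange of a whole group between the two earlier compounds did not do. The 3,4-dichlorophenyl group also separates from furan-2-yl, with a number 25.4 percentage points lower from compound 1 to compound 3 (beyond the scatter) in the same assay, so the number of atoms changed is a poor guide to the size of a step at this position among these compounds. No supporting measurement is available that bears on why the number fell.

The compounds shown leave open whether the lower number belongs to chloro in particular or would come with any group at this place, and a fluoro, a methyl or an amine there would bear on that question. They also leave open whether the step depends on the chloro already present, which a 4-chlorophenyl group, carrying only the newly added chloro, could help to settle.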